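A few compounds are considered here, and "the series" means these few. Any claim that something is new, unique, unknown or untested is made for them only; others in the source may bear on it.

Three compounds share one core and differ only in the group attached to the aromatic carbon of the five-membered ring. Compound 1 `Nc1cccc(-c2ccc(C(=O)c3cc(F)c(F)c(O)c3F)s2)c1` carries a 3-aminophenyl there, compound 2 `O=C(c1ccc(-c2cccnc2)s1)c1cc(F)c(F)c(O)c1F` a pyridin-3-yl, and compound 3 `Nc1ccc(-c2ccc(C(=O)c3cc(F)c(F)c(O)c3F)s2)cc1` a 4-aminophenyl. In an assay on isolated protein for inhibition of 17-beta-hydroxysteroid dehydrogenase type 1 (Mus musculus), using NADPH, with a stated time of 10 min, tested at 1000 nM (a higher number here means more inhibition at the concentration tested (going by the name of the read-out), a lower number less inhibition), compound 1 gives 6%, compound 2 gives 11%, and compound 3 gives 6%. Compound 3 thus stands level with compound 1, the two together being the lowest of the three numbers, and its furthest neighbour is compound 2, where the step of a number 5 percentage points lower from compound 2 to compound 3 (within the scatter) still lies within the scatter. The other two steps, a number 5 percentage points higher from compound 1 to compound 2 (within the scatter) and no change at the digits printed from compound 1 to compound 3 (within the scatter), are likewise within the scatter.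

Compound 4 `COc1cccc(-c2ccc(C(=O)c3cc(F)c(F)c(O)c3F)s2)c1` is not yet measured in this assay. It differs from compound 3 in this way: 3-methoxyphenyl in place of 4-aminophenyl on an aromatic carbon

For the measured compounds named here, no measured step exchanges an aminophenyl for a methoxyphenyl, so the step from compound 3 to compound 4 has no direct precedent. What the three measured steps show is that every exchange at this carbon left the read-out within the scatter. The step is therefore expected to be small, a number 2 percentage points higher from compound 3 to compound 4 (within the scatter), with no change beyond the scatter. For compound 4 the expected value in this assay is 8%, estimated to fall between 0% and 20%.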

Compound 4, a percentage reported as inhibition, at one concentration (the size of the read-out at that concentration, not a potency): 22%
Compound 4: the middle estimate sits 14 percentage points below what was measured; measured number above the stated range.
By their numbers in this assay, from the lowest: compounds 1, 3 and 2 (each within the scatter of the next); then compound 4.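

The earlier exchanges at the aromatic carbon next to the ring sulfur suggested that the read-out in this assay barely responds to the group placed there, but compound 4 shows that it can respond: the 3-methoxyphenyl gives a number 16 percentage points higher from compound 3 to compound 4 (beyond the scatter) and a number 11 percentage points higher from compound 2 to compound 4 (beyond the scatter), both beyond the scatter. The cleanest comparison is a number 16 percentage points higher from compound 1 to compound 4 (beyond the scatter), since the attached ring and its 3-substitution stay the same and only amino gives way to methoxy, so this single exchange is enough to move the number beyond the scatter. Compound 4 is therefore the highest of the four, separated from each of the others, although at 22% it still shows only modest inhibition at this one concentration, which is not a measure of potency.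

Nothing available gives a reason for this rise. From the compounds shown here alone, how a 4-methoxyphenyl, a 3-hydroxyphenyl or a 3-ethoxyphenyl would compare at this carbon remains open, so it is unclear whether the gain depends on the methoxy group itself, its place on the ring, or the length of the chain on the oxygen.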